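The compounds below may be only part of what the source reports. "The series", "measured", "known", "first", "only" and "open" are said of these compounds alone.

Compound 1 `O=C(/C=C/c1ccc(O)c(O)c1)CC(=O)/C=C/c1cccc(O)c1O` is one of three measured compounds that share a core, and in a functional assay, with a stated time of 30 min (on this read-out higher numbers stand for weaker inhibition and lower numbers for stronger inhibition), compound 1 gives 19000 nM. Compound 2 `O=C(/C=C/c1ccc(O)cc1)CC(=O)/C=C/c1cccc(O)c1O` differs from compound 1 by hydrogen in place of hydroxy on an aromatic carbon, and in this assay compound 2 gives 27000 nM, a step of a 1.4-fold higher number from compound 1 to compound 2 (0.15 log units; within the scatter). Compound 3 `O=C(/C=C/c1cc(O)ccc1O)CC(=O)/C=C/c1cccc(O)c1O` differs from compound 1 in its core, namely (2,5-dihydroxyphenyl in place of 3,4-dihydroxyphenyl on a double-bonded chain carbon bound to a double-bonded chain carbon), and in this assay compound 3 gives 27000 nM, which amounts to a 1.4-fold higher number from compound 1 to compound 3 (0.15 log units; within the scatter) and no change at the digits printed from compound 2 to compound 3 (within the scatter). All three numbers therefore sit close together.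

Compound 4 `O=C(/C=C/c1ccccc1O)CC(=O)/C=C/c1cc(O)ccc1O` has not yet been measured. It differs from compound 3 by hydrogen in place of hydroxy on an aromatic carbon. The same change has already been made once, from compound 1 to compound 2, where it gave a 1.4-fold higher number from compound 1 to compound 2 (0.15 log units; within the scatter); the surroundings of the changed carbon read the same in both cases, so this is the same change. Resting on that earlier step, compound 4 is expected to show a step of a 1.2-fold higher number from compound 3 to compound 4 (0.09 log units; within the scatter). Compound 4 is thus estimated at 33000 nM, with most repeats expected to fall between 15000 nM and 75000 nM.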

Compound 4, half-maximal inhibitory concentration: 48000 nM
Estimate against measurement, compound 4: 1.5-fold (0.16 log units) below; measured number inside the range.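

Putting hydrogen in place of a hydroxy group on an aromatic carbon gives, in this assay, a 1.8-fold higher number from compound 3 to compound 4 (0.25 log units; within the scatter). Set beside the earlier case of this change, the two steps agree: the same change on two cores in this assay, a 1.4-fold higher number (0.15 log units; within the scatter) from compound 1 to compound 2 and a 1.8-fold higher number (0.25 log units; within the scatter) from compound 3 to compound 4, 1.3-fold (0.10 log units) apart, within the scatter of two such steps

So the change reads the same on both cores, and nothing here suggests that the core alters its outcome, but each step lies within the scatter, so neither shows that removing this hydroxy group has any real effect on inhibition, and two cores cannot show that the agreement would hold on a third.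

Every substituent on the aromatic rings shown is a hydroxy group, so it remains open how a methoxy group, a fluorine atom or an amine would read in this assay. The chain joining the two rings is also the same throughout, which leaves open what a longer chain would do.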